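The source may report more compounds than this note shows. Statements on the series, on what has been measured and on what is new or still open speak of the compounds shown alone.

Measured so far in a physicochemical assay for solubility, with a stated time of 18 h, at pH 7.4; on this read-out higher numbers stand for higher solubility and lower numbers for lower solubility: compound 1 `COc1ccc(F)cc1CNCCCNc1ccnc2cc(Oc3cccc(N(C)C)c3)ccc12` gives 14500 nM; compound 2 `COc1cccc(CNCCCNc2ccnc3cc(Oc4cccc(N(C)C)c4)ccc23)c1O` gives 14500 nM; compound 3 `COc1cccc(CNCCCNc2ccnc3cc(-c4cc(C(F)(F)F)cc(C(F)(F)F)c4)ccc23)c1O` gives 32000 nM.

Compound 1 and compound 2 share one core and differ only in 5-fluoro-2-methoxyphenyl in place of 2-hydroxy-3-methoxyphenyl on a saturated chain carbon bound to an amine nitrogen. On that pair this assay shows no change at the digits printed from compound 2 to compound 1 (within the scatter). Compound 3 carries a different core; the difference between the two cores is not broken down here. In this assay compound 3 holds the highest of the three numbers.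

Compound 4 `COc1ccc(F)cc1CNCCCNc1ccnc2cc(-c3cc(C(F)(F)F)cc(C(F)(F)F)c3)ccc12` has not yet been measured in this assay. It differs from compound 3 by 5-fluoro-2-methoxyphenyl in place of 2-hydroxy-3-methoxyphenyl on a saturated chain carbon bound to an amine nitrogen, the same change at the same place as the earlier pair. The step expected for it, no change at the digits printed from compound 3 to compound 4 (within the scatter), rests on the earlier step, no change at the digits printed from compound 2 to compound 1 (within the scatter). Compound 4 is therefore expected to give about 32000 nM, estimated between 16000 nM and 64000 nM.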

Compound 4, solubility: 32000 nM
Compound 4: middle estimate and measured number agree at the digits printed, within the range that was stated.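

With 5-fluoro-2-methoxyphenyl in place of 2-hydroxy-3-methoxyphenyl, this assay shows no change at the digits printed from compound 3 to compound 4 (within the scatter) just as it shows no change at the digits printed from compound 2 to compound 1 (within the scatter) on the other core, so in both pairs the number stays within the scatter. This is agreement on two cores only and does not show that the change would leave the number unmoved on any other core in the series. Nothing measured here says why the two pairs agree.

The compounds shown leave open what an amine or a carboxylic acid at this place, on a saturated chain carbon bound to an amine nitrogen, would do on either core. Going by these compounds, a longer chain remains open as well.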